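This account rests on a few compounds, and the source may have more. Where it says the series, first, only, none or still open, it means among the compounds named here.

Measured in an ADME assay on microsomes from liver (Homo sapiens) for metabolic stability, with a stated time of 30 min; on this read-out higher numbers stand for a more stable compound and lower numbers for a less stable compound:
- compound 1 `CC(=O)N[C@@H](C)/C=C/c1ccc(Oc2ccc3nc(C)sc3c2Cl)nc1`: 87%
- compound 2 `CC(=O)N[C@@H](C)/C=C/c1ccc(Oc2cc3sc(C)nc3cc2Cl)nc1`: 94%

Only these two compounds have been measured so far. Compound 1, at 87%, lies within the usual scatter of compound 2, at 94%, so the two numbers cannot be told apart. Both sit near the top of the scale.

The next compound to be measured is compound 3 `CC(=O)N[C@@H](C)/C=C/c1ccc(Oc2ccc3nc(C(C)C)sc3c2Cl)nc1`, which keeps the core of compound 1 and changes a single group: isopropyl in place of methyl on an aromatic carbon. Isopropyl stands in place of methyl on an aromatic carbon of a five-membered aromatic ring with 1 nitrogen and 1 sulfur, next to the ring nitrogen and next to the ring sulfur.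

For the measured compounds named here, no two measured compounds differ in just one place, so the data give no direct guide to the size of this change. With compound 1 at 87%, little room remains upward. In this assay a modest downward move is therefore expected, about the size of the usual scatter, and the estimated step is a number 9 percentage points lower from compound 1 to compound 3 (within the scatter). For compound 3 the expected value is 78%, with an estimated range from 60% to 92%.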

Compound 3, percent of the compound remaining: 83%
Estimate against measurement, compound 3: 5 percentage points below; the measured number falls inside the stated range.
By their numbers in this assay, from the lowest: compounds 3, 1 and 2 (each within the scatter of the next, the first and the last beyond it).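

In this assay, for the compounds shown here, compound 1 and compound 3 form the first pair that differs in only one place, giving a direct reading for the aromatic carbon of the five-membered aromatic ring, next to the ring nitrogen and next to the ring sulfur. Isopropyl in place of methyl at this carbon gives a number 4 percentage points lower from compound 1 to compound 3 (within the scatter), so moving from 1 heavy atom to 3 heavy atoms here produces no difference that can be told from the usual scatter on this read-out. No supporting evidence is available to explain this result.

The compounds shown leave open whether this position would tolerate groups of a different kind, such as a tert-butyl group, a longer chain, an amine or a carboxylic acid, while the percent remaining stayed in the same range. As far as these compounds go, it also remains open whether isopropyl in place of methyl on the core of compound 2 would give a step of similar size, since this single pair speaks only for the core of compound 1.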